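This account rests on a few compounds, and the source may have more. Where it says the series, first, only, none or still open, it means among the compounds named here.

Measured compounds:
Compound 1, `CCCCNc1nc(N)nc2c1CN(Cc1cccc(Cl)c1Cl)CC2`: in an assay on HEK293 cells for agonist activity at Toll-like receptor 8 (Homo sapiens), read by a luciferase reporter, with a stated time of 6 h (on this read-out lower numbers stand for an effect already at smaller amounts and higher numbers for an effect only at larger amounts of compound), compound 1 gives 0.18 uM.
Compound 2, `CCCCNc1nc(N)nc2c1CN(Cc1ccc(OC)cc1)CC2`: compound 2 gives 0.08 uM.
Compound 3, `CCCCNc1nc(N)nc2c1CN(Cc1ccccn1)CC2`: compound 3 gives 0.07 uM.

Compound 3 has the lowest number of the three, but its gap to compound 2 lies within the scatter, so these two cannot be ranked against each other. Both differ from compound 1 by steps beyond the scatter: a 2.3-fold lower number from compound 1 to compound 2 (0.35 log units; beyond the scatter) and a 2.6-fold lower number from compound 1 to compound 3 (0.41 log units; beyond the scatter), while a 1.1-fold lower number from compound 2 to compound 3 (0.06 log units; within the scatter).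

Compound 4, `CCCCNc1nc(N)nc2c1CN(C(=O)c1ccncc1)CC2`, has not yet been measured. It differs from compound 3 in one place: (pyridin-4-yl)carbonyl in place of (pyridin-2-yl)methyl on an amine nitrogen in a ring. Each of the three measured steps exchanges one aromatic ring for another on the same saturated chain carbon, and all remain modest. Among the measured compounds shown here, none of them introduces a carbonyl on the amine nitrogen in a ring, so no measured step shows how such a change plays out here. Going by these compounds, the aromatic swaps suggest the ring itself matters little, but the carbonyl is untested. Compound 4 is therefore expected to give 0.5 uM, between 0.1 uM and 3 uM, which is an estimated step of a 7.1-fold higher number from compound 3 to compound 4 (0.85 log units; beyond the scatter), with wide uncertainty in either direction.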

Compound 4, minimum effective concentration: > 25 uM
Compound 4: no number, only a limit; the forecaster's own chance of this, stated with the estimate: 25%; middle value at least 50-fold (1.69 log units) from the limit.
By their numbers in this assay, from the lowest: compounds 3 and 2 (each within the scatter of the next); then compound 1. At a limit, above all of these: compound 4.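

In this assay, among the compounds shown here, putting (pyridin-4-yl)carbonyl in place of (pyridin-2-yl)methyl on an amine nitrogen in a ring brings an at least 350-fold higher number from compound 3 to compound 4 (2.55 log units; beyond the scatter) and so far outruns the earlier steps, which exchanged one aromatic ring for another on the same saturated chain carbon and stayed modest. This position is therefore not indifferent to change: the three rings held on a saturated chain carbon all gave low numbers, while this carbonyl-linked ring did not. The value of compound 4 is a limit and not a number: the limit of > 25 uM in this assay, at which 1 of the 4 values shown sits.

The step alters the link and the point of attachment on the pyridine ring together, and the compounds shown do not separate the two. A (pyridin-4-yl)methyl group or a (pyridin-2-yl)carbonyl group on the same nitrogen would show which of them matters.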